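The source may report more compounds than this note shows. Statements on the series, on what has been measured and on what is new or still open speak of the compounds shown alone.

Compound 1, with the structure `Fc1ccc(-c2nc3cccnc3o2)cc1`, is the reference point of this small set. In a functional assay on the whole organism for inhibition, with Rattus norvegicus as the target, at a dose of 30 mg/kg (a lower number here means less inhibition, a higher number more inhibition at the dose given (going by the name of the read-out)), compound 1 gives 27%, the highest of the three numbers recorded. Compound 3, with the structure `N#Cc1cccc(C#N)c1-c1nc2ncccc2o1`, gives 19% in this assay, a result that sits within the usual scatter of the number for compound 1, so the two cannot be told apart. Compound 2, with the structure `COc1ccccc1-c1nc2ncccc2o1`, gives 9% in this assay, and the gap to compound 1 lies beyond the scatter.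

Compound 4, with the structure `COc1ccc(-c2nc3cccnc3o2)cc1`, has not yet been measured. It differs from compound 1 in one place: methoxy in place of fluoro on an aromatic carbon. Within the data shown here, no measured pair in this set shows that exchange, so there is no step to lean on. The three numbers at hand all stay modest, and nothing among them suggests that a change of this kind moves the read-out far. The expected step from compound 1 to compound 4 is therefore a number 2 percentage points lower from compound 1 to compound 4 (within the scatter), within the scatter rather than beyond it. On this basis compound 4 is estimated to give 25% in this assay, with a range from 8% to 42%.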

Compound 4, a percentage reported as inhibition, in the whole organism at one dose (the size of the read-out at that dose, not a potency): 29%
Compound 4: middle estimate off by 4 percentage points, on the low side, and the stated range covers the measured number.
By their numbers in this assay, from the lowest: compounds 2, 3, 1 and 4 (each within the scatter of the next, the first and the last beyond it).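

In this assay, methoxy in place of fluoro on an aromatic carbon, para to a group of 9 heavy atoms, gives a number 2 percentage points higher from compound 1 to compound 4 (within the scatter). Among these compounds, this is the first pair in the set that differs in one place, and it shows that at this position a methoxy group, with its hydrogen-bond acceptor, cannot be told apart from fluoro, which has none. No measurement at hand bears on the cause of this result.

The compounds shown leave open whether an amine, a carboxylic acid or a longer chain such as butoxy at this same position would also leave the read-out within the scatter. Compound 2 and compound 3 differ from this pair in more than one place, so they do not settle that question.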